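Cytotoxicity Limits Across Varied Amine Side Chains

The compounds below may be only part of what the source reports. "The series", "measured", "known", "first", "only" and "open" are said of these compounds alone.

Compound 1 `Cc1nc2c(c(-c3cc(F)c4c(c3C)CCCO4)c1[C@H](OC(C)(C)C)C(=O)O)CN(CCCc1cccc(F)c1)CC2` gave > 40000 nM in an ADME assay on MT2 cells (Homo sapiens) for cytotoxicity, read by XTT assay, with a stated time of 4 days (on this read-out higher numbers stand for lower toxicity in this test and lower numbers for higher toxicity in this test), a limit of the assay.
Compound 2 `Cc1nc2c(c(-c3cc(F)c4c(c3C)CCCO4)c1[C@H](OC(C)(C)C)C(=O)O)CN(CCCc1ccncc1)CC2` gave > 40000 nM, again a limit.
Compound 3 `Cc1nc2c(c(-c3cc(F)c4c(c3C)CCCO4)c1[C@H](OC(C)(C)C)C(=O)O)CN(CC1CC1c1ccccc1)CC2` gave > 40000 nM, also a limit.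

Compound 3 thus stands at the same limit as the other two; no number is known for it, and all shown values share (the limit of > 40000 nM in this assay, at which 3 of the 3 values shown sit). The step to compound 4 `Cc1nc2c(c(-c3cc(F)c4c(c3C)CCCO4)c1[C@H](OC(C)(C)C)C(=O)O)CN(CCCc1ccccc1F)CC2` is 2-(2-fluorophenyl)ethyl in place of 2-phenylcyclopropyl on a saturated chain carbon bound to an amine nitrogen in a ring. The measured steps that bear on it, a step that the two limits leave unreadable from compound 1 to compound 3 and a step that the two limits leave unreadable from compound 2 to compound 3, are both unreadable because the limit of > 40000 nM in this assay, at which 3 of the 3 values shown sit, hides their size. Among the measured compounds shown here, no step in this set has yet moved any value off the limit, so compound 4 is expected to show the same, with a step that the limit leaves unreadable from compound 3 to compound 4 no step beyond the scatter. Compound 4 is estimated at 60000 nM, between 30000 nM and 200000 nM.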

Compound 4, half-maximal cytotoxic concentration: > 40000 nM
Compound 4: no number, only a limit; the forecaster's own chance of this, stated with the estimate: 85%; the middle value is on the limit's open side.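

Compound 4 also gave only a limit in this assay, so its steps from compound 1, compound 2 and compound 3 cannot be read: the limit of > 40000 nM in this assay, at which 4 of the 4 values shown sit.

The compounds shown leave open whether any of these side chains differs from another in this assay.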